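This account rests on a few compounds, and the source may have more. Where it says the series, first, only, none or still open, it means among the compounds named here.

Measured so far in an assay on isolated protein for inhibition of Indoleamine 2,3-dioxygenase 1 (Homo sapiens), with a stated time of 60 min, tested at 10 uM; a lower number here means less inhibition, a higher number more inhibition at the concentration tested (going by the name of the read-out):
- compound 1 `Clc1ccc2[nH]c(SCc3ccccc3Oc3ccccc3)nc2c1` gives 30%
- compound 2 `Clc1ccc2[nH]c(SCc3ccccc3CCc3ccccc3)nc2c1` gives 47%
- compound 3 `Clc1ccc2[nH]c(SCc3ccccc3C#Cc3ccccc3)nc2c1` gives 52%

Compound 3 holds the highest of the three numbers in this assay, but its lead over compound 2 is within the scatter (a number 5 percentage points higher from compound 2 to compound 3 (within the scatter)), so the two cannot be ordered; only compound 1 sits clearly below it (a number 22 percentage points higher from compound 1 to compound 3 (beyond the scatter)). The next compound is compound 4 `Clc1ccc2[nH]c(SCc3ccccc3SCc3ccccc3)nc2c1`, which differs from compound 3 in one place: benzylsulfanyl in place of 2-phenylethynyl on an aromatic carbon.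

All three measured steps bear on this change, since each swaps the group at the same position. The phenoxy group gave the lowest number, and replacing it by phenethyl (a number 17 percentage points higher from compound 1 to compound 2 (beyond the scatter)) or by 2-phenylethynyl (a number 22 percentage points higher from compound 1 to compound 3 (beyond the scatter)) raised the read-out by a modest amount, while phenethyl against 2-phenylethynyl (a number 5 percentage points higher from compound 2 to compound 3 (within the scatter)) made no difference beyond the scatter. Benzylsulfanyl brings a heteroatom into the linker, as phenoxy does, but keeps a two-atom link to the outer ring, as phenethyl does. A modest downward step is therefore expected for compound 4, a number 12 percentage points lower from compound 3 to compound 4 (beyond the scatter), with a wide range. The estimate for compound 4 in this assay is 40%, expected between 25% and 55%.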

Compound 4, a percentage reported as inhibition, at one concentration (the size of the read-out at that concentration, not a potency): 19%
Beside the measured number, compound 4's estimate is 21 percentage points above it, and the stated range ends above it.
By their numbers in this assay, from the lowest: compound 4; then compound 1; then compounds 2 and 3 (each within the scatter of the next).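

In this assay, benzylsulfanyl gives the lowest number of the four groups at this position, on an aromatic carbon ortho to a large group, with every step beyond the scatter: against 2-phenylethynyl (a number 33 percentage points lower from compound 3 to compound 4 (beyond the scatter)), against phenethyl (a number 28 percentage points lower from compound 2 to compound 4 (beyond the scatter)) and against phenoxy (a number 11 percentage points lower from compound 1 to compound 4 (beyond the scatter)). Since 2-phenylethynyl and benzylsulfanyl both hold 8 heavy atoms and a six-membered aromatic ring, neither that count nor the presence of the outer ring sets the number, and among these four compounds the two groups with a heteroatom in the linker, in compound 1 and compound 4, stand below the two all-carbon linkers of compound 2 and compound 3. No measurement at hand accounts for these steps.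

Still open, as far as these compounds go, is whether this split follows the heteroatom in the linker or some other feature of these groups. An amine nitrogen or a sulfone in the linker, or a longer chain to the outer ring, would test this.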